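Propargyl to methyl at sulfur: an expected loss

The source may report more compounds than this note shows. Statements on the series, on what has been measured and on what is new or still open speak of the compounds shown alone.

The measured compounds:
compound 1, `C[Se]c1c(SCC#CCO)cnc2ccccc12`; in a functional assay on P388 cells (Mus musculus) for cytotoxicity, read by MTT assay, with a stated time of 72 h (on this read-out higher numbers stand for weaker inhibition and lower numbers for stronger inhibition), compound 1 gives 19.8 ug/mL.
compound 2, `C#CC[Se]c1c(SCC#CCO)cnc2ccccc12`; in this assay compound 2 gives 2.5 ug/mL.
compound 3, `C#CCSc1cnc2ccccc2c1[Se]CC#CCO`; in this assay compound 3 gives 3.1 ug/mL.

Compound 2 and compound 1 differ in one place, (hydrogen in place of ethynyl on a saturated chain carbon bound to a selenium atom), and that change gave a 7.9-fold higher number from compound 2 to compound 1 (0.90 log units; beyond the scatter). Compound 3 shares its atoms with compound 2, joined differently; the difference between the two cores is not broken down here. The values of compound 2 and compound 3 lie within the scatter of each other, so no order between them is claimed.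

The unmeasured compound 4, `CSc1cnc2ccccc2c1[Se]CC#CCO`, is derived from compound 3 by hydrogen in place of ethynyl on a saturated chain carbon bound to a sulfur. This is the same kind of change as that from compound 2 to compound 1, but not the same: there the saturated chain carbon was bound to a selenium atom, here it is bound to a sulfur. Among the compounds with values here, only the one earlier step, a 7.9-fold higher number from compound 2 to compound 1 (0.90 log units; beyond the scatter), is available as a guide, and it rests on a single pair, so the expectation for compound 4 carries a wide range.

For compound 4 in this assay the expected step is a 6.5-fold higher number from compound 3 to compound 4 (0.81 log units; beyond the scatter), because compound 3 stands at 3.1 ug/mL and the earlier step was a 7.9-fold higher number from compound 2 to compound 1 (0.90 log units; beyond the scatter). Compound 4 is therefore estimated at 20 ug/mL, with a range from 7 ug/mL to 55 ug/mL.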

Compound 4, concentration for 50% inhibition: 2.6 ug/mL
The estimate for compound 4 lay 7.7-fold (0.89 log units) above the measured number; the measured number lies below the stated range.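

In this assay the change from propargyl to methyl on the saturated chain carbon bound to a sulfur gave a 1.2-fold lower number from compound 3 to compound 4 (0.08 log units; within the scatter) and so left the two values unseparated, whereas the same kind of change on the carbon bound to a selenium atom had given a 7.9-fold higher number from compound 2 to compound 1 (0.90 log units; beyond the scatter) and a clear loss of potency. The size of the earlier step therefore did not carry over from one core to the other, and the two steps differ by more than their scatter: the same change on two cores in this assay, a 7.9-fold higher number (0.90 log units; beyond the scatter) from compound 2 to compound 1 and a 1.2-fold lower number (0.08 log units; within the scatter) from compound 3 to compound 4, 9.4-fold (0.98 log units) apart, beyond the scatter of two such steps. Within the data shown here, this does not show what sets the two steps apart, and with only one pair on each core it cannot be said whether the atom bearing the changed group or some other feature of the core is responsible.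

The compounds shown leave open how a longer chain, such as ethyl or butyl, would behave in place of methyl on either the sulfur or the selenium atom. They also leave open whether the contrast between the two cores would persist if an amine took the place of the hydroxyl group on the chain that stayed unchanged.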